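Trimming a Sulfonamide Tail in a Kinase Inhibitor Series

The source may hold more compounds than are shown below. What is called first, only, known or untested is meant among the compounds shown, and "the series" means these compounds.

Of the compounds shown here, three sharing one core have been measured in an assay for inhibition of serine/threonine-protein kinase PLK2 (Homo sapiens), read by FRET and Z'-LYTE, with a stated time of 1 h; a higher number here means a weaker inhibitor, a lower number a stronger inhibitor. Compound 1 `CC[C@@H]1C(=O)N(C)c2cnc(-n3ccc4cc(F)ccc43)nc2N1C1CCCC1` gives 969 nM, and compound 3 `CCC1C(=O)N(C)c2cnc(-n3ccc4cc(C(=O)NC)ccc43)nc2N1c1ccn(C)n1` gives 218 nM. Compound 2 `CC[C@@H]1C(=O)N(C)c2cnc(Nc3ccc(S(=O)(=O)NCCO)cc3)nc2N1C1CCCC1`, which carries an anilino group bearing a substituted sulfonamide, gives 7.86 nM, the lowest of the three numbers: its gap to compound 3 and its larger gap to compound 1 both lie beyond the scatter of repeated measurements, so compound 2 is the strongest inhibitor of the set.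

The next compound, compound 4 `CC[C@@H]1C(=O)N(C)c2cnc(Nc3ccc(S(N)(=O)=O)cc3)nc2N1C1CCCC1`, keeps everything in compound 2 except for one change on the sulfonamide: hydrogen in place of 2-hydroxyethyl on a sulfonamide nitrogen. The group that leaves is small and sits at the end of the molecule; the rest of the structure, including the anilino link and the core, is untouched.

Among the compounds with values here, no measured pair in this set differs by a change of this kind, so there is no directly comparable step to lean on. A small group at a distant end of the molecule is expected to move the number little, in either direction, and the step of a 1.1-fold lower number from compound 2 to compound 4 (0.05 log units; within the scatter) is expected to stay within the usual scatter. For compound 4 the estimated value is 7 nM, with a range from 2.5 nM to 20 nM.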

Compound 4, half-maximal inhibitory concentration: 10.2 nM
Estimate against measurement, compound 4: 1.5-fold (0.16 log units) below, and the stated range covers the measured number.
By their numbers in this assay, from the lowest: compounds 2 and 4 (each within the scatter of the next); then compound 3; then compound 1.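

Replacing the 2-hydroxyethyl group on the sulfonamide nitrogen with hydrogen gives a 1.3-fold higher number from compound 2 to compound 4 (0.11 log units; within the scatter) in this assay, so the two compounds cannot be told apart in this measurement. Within the data shown here, no two of the earlier compounds differed in only one place, which makes this the first reading of a single group in the set: at this position, the 2-hydroxyethyl chain, with its hydrogen-bond donor and acceptor, is not needed to keep the number at the level of compound 2. There is no independent measurement here that could explain this result, so it stands as an observation without a known cause.

This single step compares only hydrogen and 2-hydroxyethyl, so it cannot show how a longer chain, a carboxylic acid or an amine on the same sulfonamide nitrogen would read. Going by these compounds, it also cannot be carried over to compound 1 or compound 3, neither of which has a sulfonamide, so whether other groups on this nitrogen would matter in the wider series remains open.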